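The source may report more compounds than this note shows. Statements on the series, on what has been measured and on what is new or still open speak of the compounds shown alone.

Measured so far:
- compound 1, `CC(C)[C@H](NC(=S)Nc1ccccc1)c1nc2ccccc2[nH]1` — 12300 nM
- compound 2, `C[C@H](NC(=S)NCc1ccccc1)c1nc2ccccc2[nH]1` — 226000 nM
- compound 3, `C[C@@H](NC(=S)Nc1ccccc1)c1nc2ccccc2[nH]1` — 22100 nM

In a functional assay on DU-145 cells (Homo sapiens) for cytotoxicity, read by MTT assay (a higher number here means a weaker inhibitor, a lower number a stronger inhibitor), compound 3 gives 22100 nM. On the three numbers this is the second highest: the nearest is compound 1 at 12300 nM, a gap that lies within the scatter of repeated measurements, so no order between compound 1 and compound 3 can be read from it. The furthest is compound 2 at 226000 nM, a gap well beyond the scatter; compound 2 and compound 3 differ in more than one place, so that gap is not assigned to any single change.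

Compound 4, `C[C@H](NC(=S)Nc1ccccc1)c1nc2ccccc2[nH]1`, is the next compound to be measured in this assay. It differs from compound 3 as follows: the two compounds have the same atoms and bonds and differ only in configuration as drawn: 1 of 1 stereo elements differ; a stereocentre at a saturated chain carbon is drawn R in compound 3 and S in compound 4. Going by the values given here, no pair of measured compounds differs by this kind of change alone, so there is no step on record from which to read a size or a direction. In the absence of such a reference, the step from compound 3 to compound 4 is expected to be a 1.1-fold lower number from compound 3 to compound 4 (0.04 log units; within the scatter), that is, no shift beyond the scatter in either direction, with the range widened to allow for a real but unrecorded dependence on configuration. Compound 4 is therefore estimated at 20000 nM, with a range from 6000 nM to 70000 nM.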

Compound 4, half-maximal inhibitory concentration: "not active" (no number reported)
Compound 4: no number reported, so the estimate cannot be set against anything.
By their numbers in this assay, from the lowest: compounds 1 and 3 (each within the scatter of the next); then compound 2.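

In this assay compound 4 is recorded as "not active" with no number reported, while compound 3 gives 22100 nM, so no step can be read between compound 3 and compound 4. Going by these compounds, whether the configuration at the stereocentre changes the read-out, and by how much, stays open, and the structures point only to this: the fact that compounds 3 and 4 differ only in the configuration as drawn.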